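A few compounds are considered here, and "the series" means these few. Any claim that something is new, unique, unknown or untested is made for them only; others in the source may bear on it.

Measured so far:
- compound 1 `C=CCOc1c(C)c(C)c2c(c1C)CCC(C)(COc1cccc(/C=C3\SC(=O)NC3=O)c1)O2` gives 75% in a functional assay on MCF7 cells (Homo sapiens), tested at 7.5 uM; on this read-out lower numbers stand for a stronger effect and higher numbers for a weaker effect at the one concentration tested
- compound 2 `CC(C)=CCOc1c(C)c(C)c2c(c1C)CCC(C)(COc1ccc(/C=C3\SC(=O)NC3=O)cc1F)O2` gives 64% in this assay

Of these two numbers, compound 2 stands lowest, and the gap to compound 1 lies beyond the usual scatter of repeated measurements. Among the compounds with values here, no computed step between the two measured compounds is available, so what the fluoro-bearing ring contributes on its own cannot be read from them.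

Compound 3 `CC(C)=CCOc1c(C)c(C)c2c(c1C)CCC(C)(COc1ccc(/C=C3\SC(=O)NC3=O)cc1C)O2` differs from compound 2 by methyl in place of fluoro on an aromatic carbon. A swap of one small group for another of the same size is expected to move the read-out little, so the step from compound 2 to compound 3 is expected to be a number 2 percentage points higher from compound 2 to compound 3 (within the scatter), within the scatter. Compound 3 is therefore expected to give about 66%, somewhere between 48% and 84%.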

Compound 3, a percentage reported as activity, at one concentration (the size of the read-out at that concentration, not a potency): 27%
Compound 3: middle estimate off by 39 percentage points, on the high side, and the stated range ends above it.
By their numbers in this assay, from the lowest: compound 3; then compound 2; then compound 1.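

At this aromatic carbon, ortho to a large group, the read-out in this assay responds strongly to a very small change: methyl in place of fluoro brings a number 37 percentage points lower from compound 2 to compound 3 (beyond the scatter) for the exchange of one heavy atom. Neither group has hydrogen-bond donors or acceptors, so those counts do not separate them. Nothing available here explains the step.

Going by these compounds, whether other groups at this carbon, such as chloro, methoxy or ethyl, would go further remains open. So does whether the exchange would act alike on the core of compound 1.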